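The source may report more compounds than this note shows. Statements on the series, on what has been measured and on what is new or still open speak of the compounds shown alone.

Compound 1 `O=C1Nc2ccccc2/C1=N/NC(=S)N1CCN(c2ccccc2)CC1` gives 24900 nM in a functional assay on MCF7 cells (Homo sapiens) for inhibition, read by MTT assay, with a stated time of 72 h; a lower number here means a stronger inhibitor, a higher number a weaker inhibitor. Within the data shown here, compound 2 `Cc1ccc2c(c1)/C(=N/NC(=S)N1CCN(c3ccccc3)CC1)C(=O)N2` gives 14900 nM, and compound 3 `O=C1Nc2ccc(Cl)cc2/C1=N/NC(=S)N1CCN(c2ccccc2)CC1` gives 10400 nM, the lowest of the three numbers, though only the step of a 2.4-fold lower number from compound 1 to compound 3 (0.38 log units; beyond the scatter) lies beyond the scatter; a 1.7-fold lower number from compound 1 to compound 2 (0.22 log units; within the scatter) and a 1.4-fold lower number from compound 2 to compound 3 (0.16 log units; within the scatter) do not. Compound 4 `O=C1Nc2ccc(Cl)cc2/C1=N/NC(=S)N1CCN(c2ccc(Cl)cc2)CC1` differs from compound 3 by chloro in place of hydrogen on an aromatic carbon. Among the measured compounds shown here, the one measured step of the same kind, a 2.4-fold lower number from compound 1 to compound 3 (0.38 log units; beyond the scatter), was modest, but it sat on the shared core rather than on the phenyl, so it bears only loosely here. A modest lowering or none beyond the scatter is expected in this assay. Compound 4 is estimated at 6500 nM, range 3000 nM to 15000 nM. The expected step is a 1.6-fold lower number from compound 3 to compound 4 (0.20 log units; within the scatter).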

Compound 4, half-maximal inhibitory concentration: 13100 nM
For compound 4 the middle estimate is 2.0-fold (0.30 log units) below the measured one, within the range that was stated.
By their numbers in this assay, from the lowest: compounds 3, 4, 2 and 1 (each within the scatter of the next, the first and the last beyond it).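

The phenyl to 4-chlorophenyl change on compound 3 gives a 1.3-fold higher number from compound 3 to compound 4 (0.10 log units; within the scatter) in this assay, so chloro at this position leaves no readable change in this assay. The earlier chloro step on the shared core, a 2.4-fold lower number from compound 1 to compound 3 (0.38 log units; beyond the scatter), lies beyond the scatter, while this one does not, so the two sites cannot be treated as one.

Open, going by these compounds, is whether 4-chlorophenyl on the core of compound 1 would read the same, and whether an amine or a carboxylic acid at this position would move the number beyond the scatter. No measurement at hand offers a reason for this result.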